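Swapping an acetamido for trifluoromethyl on the benzyl ring

The source may report more compounds than this note shows. Statements on the series, on what has been measured and on what is new or still open speak of the compounds shown alone.

Of the compounds shown here, three that share a core have been measured in an assay for inhibition of MAP kinase-interacting serine/threonine-protein kinase 2 (Homo sapiens), read by luminescence and ADP-Glo, with a stated time of 2 h; on this read-out lower numbers stand for stronger inhibition and higher numbers for weaker inhibition. Compound 1, `NC(=O)c1cccc(Cn2cc(-c3ccc4cn[nH]c4c3)ccc2=O)c1`, gives 106 nM. Compound 2, `Nc1n[nH]c2cc(-c3ccc(=O)n(Cc4ccccc4F)c3)ccc12`, which carries an amino group on its core and a fluorine on its benzyl ring, gives 4 nM. Compound 3, `CC(=O)Nc1cccc(Cn2cc(-c3ccc4cn[nH]c4c3)ccc2=O)c1`, gives 43 nM; it stands second highest of the three numbers, with compound 1 nearest and compound 2 furthest below it.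

Within the data shown here, the single measured step, a 2.5-fold lower number from compound 1 to compound 3 (0.39 log units; beyond the scatter), shows that exchanging one group on the benzyl ring for another of similar size can move the number modestly.

Compound 4, `O=c1ccc(-c2ccc3cn[nH]c3c2)cn1Cc1cccc(C(F)(F)F)c1`, differs from compound 3 in one place: trifluoromethyl in place of acetamido on an aromatic carbon. Here a group with one donor and one acceptor gives way to one with neither, so the measured step from compound 1 to compound 3 bears on it only loosely. Compound 2 also differs on the core, and it is not comparable. The expectation for compound 4 is therefore uncertain, and a step of a 2.3-fold higher number from compound 3 to compound 4 (0.37 log units; beyond the scatter) is estimated, leaning toward a higher number. Compound 4 is expected to give about 100 nM, within a range from 30 nM to 350 nM.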

Compound 4, half-maximal inhibitory concentration: 32 nM
Estimate against measurement, compound 4: 3.1-fold (0.49 log units) above, and the stated range covers the measured number.
By their numbers in this assay, from the lowest: compound 2; then compounds 4 and 3 (each within the scatter of the next); then compound 1.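

In this assay, trifluoromethyl in place of acetamido gives a 1.3-fold lower number from compound 3 to compound 4 (0.13 log units; within the scatter) and so the two groups cannot be told apart on this read-out. This shows that at this place on the benzyl ring, the hydrogen-bond donor and acceptor counted on acetamido are not required for a number in this range, since trifluoromethyl has neither. Trifluoromethyl in place of carbamoyl gives a 3.3-fold lower number from compound 1 to compound 4 (0.52 log units; beyond the scatter) and so, of the three groups tried at this place, carbamoyl alone is separated from both of the others by more than the scatter, and no measurement shown here accounts for that separation.

What the compounds leave open is whether a carboxylic acid, an amine or a methoxy group at this same place would stay close to acetamido and trifluoromethyl or fall nearer to carbamoyl. Going by these compounds, compound 2 differs from compound 4 in more than one place, so it remains unknown how an amino group on the shared core would act alongside trifluoromethyl on the benzyl ring.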